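The compounds below may be only part of what the source reports. "The series", "measured", "known", "first", "only" and "open" are said of these compounds alone.

Compound 1 `COc1cccc(-c2ccc(S(=O)(=O)Nc3cc(N4C[C@@H](C)N[C@@H](C)C4)ccc3OC)cc2)c1` gives 1 in a functional assay for agonist activity at growth hormone secretagogue receptor type 1 (Homo sapiens), read by FLIPR; a lower number here means a smaller maximal response, a higher number a larger maximal response. Compound 2 `COc1ccc(N2C[C@@H](C)N[C@@H](C)C2)cc1NS(=O)(=O)c1ccc(-c2cccs2)cc1` gives 1.

Compound 2 stands level with compound 1 in this assay; the step of no change at the digits printed from compound 1 to compound 2 (within the scatter) lies within the scatter. Compound 3 `COc1ccc(N2C[C@@H](C)N[C@@H](C)C2)cc1NS(=O)(=O)c1ccc(OCc2ccccc2)cc1` differs from compound 2 in one place: benzyloxy in place of thiophen-2-yl on an aromatic carbon. Going by the values given here, the only measured step that bears on the change is the one from compound 1 to compound 2, where swapping one large group at this aromatic carbon for another left the maximal response unchanged. Benzyloxy in place of thiophen-2-yl is therefore expected to give a step a number 0.10 lower from compound 2 to compound 3 (within the scatter) that stays within the scatter. Compound 3 is estimated at 0.9, with a range from 0.6 to 1.1.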

Compound 3, intrinsic activity: the largest response reached, as a fraction of the reference agonist's: 0.8
The estimate for compound 3 lay 0.10 above the measured number; the range from low to high includes it.
By their numbers in this assay, from the lowest: compound 3; then compounds 1 and 2 (each within the scatter of the next).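

Benzyloxy is the first group at this aromatic carbon, para to a large group, to shift the read-out in this assay, giving a number 0.20 lower from compound 2 to compound 3 (beyond the scatter) and a number 0.20 lower from compound 1 to compound 3 (beyond the scatter). Thiophen-2-yl and 3-methoxyphenyl had stood level, so the position does not accept every large group equally. Nothing available accounts for the drop. The compounds shown leave open whether it follows from the oxygen of benzyloxy or from its ring. They also leave open how an amine, a carboxylic acid or a longer chain would fare at this carbon.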